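A Methyl Step Starting from an Assay Limit

This account rests on a few compounds, and the source may have more. Where it says the series, first, only, none or still open, it means among the compounds named here.

Compound 2 `Clc1cc2nc(Br)n(Cc3ccccc3)c2cc1Cl` stands at > 100000 nM in a functional assay on CEM-SS cells (Homo sapiens) for cytotoxicity (a higher number here means a weaker inhibitor, a lower number a stronger inhibitor), which is a limit and not a number. Compound 3 `Cc1ccc(Cn2c(Br)nc3cc(Cl)c(Cl)cc32)cc1` also gives only a limit, > 100000 nM. Within the data shown here, compound 1 `Cc1cccc(Cn2c(N)nc3cc(Cl)c(Cl)cc32)c1` gives a true number, 48000 nM, though no measured step connects it to compound 4. Compound 4 `Cc1cccc(Cn2c(Br)nc3cc(Cl)c(Cl)cc32)c1` differs from compound 2 by methyl in place of hydrogen on an aromatic carbon, with the methyl meta to a large group. Among the measured compounds shown here, the one measured step that bears on this change is a step that the two limits leave unreadable from compound 2 to compound 3, also methyl in place of hydrogen on an aromatic carbon, and it offers no size. The step expected in this assay is therefore a number no higher from compound 2 to compound 4 (the limit leaves the size open), with no step beyond the scatter anticipated in either direction. Compound 4 is estimated at 100000 nM, with an expected range of 45000 nM to 200000 nM.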

Compound 4, half-maximal inhibitory concentration: > 100000 nM
Compound 4: no number, only a limit; the forecaster's own chance of this, stated with the estimate: 70%; the middle value lies on the limit itself.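

Compound 4 stands at a limit of > 100000 nM, so methyl in place of hydrogen on an aromatic carbon has now met the limit at two positions on the ring. Neither methyl step can be read, because both ends of each step are limits in this assay: the limit of > 100000 nM in this assay, at which 3 of the 4 values shown sit.

Among these compounds, with the methyl kept, the one readable comparison is an at least 2.0-fold higher number from compound 1 to compound 4 (0.31 log units; beyond the scatter), for bromo in place of amino on an aromatic carbon.

The compounds shown leave open how the methyl counts when amino stands on the core, and how an ethyl or methoxy group at this carbon, or a carboxylic acid in place of the bromo, would read in this assay.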